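Swapping Methoxy for Dimethylamino

A few compounds are considered here, and "the series" means these few. Any claim that something is new, unique, unknown or untested is made for them only; others in the source may bear on it.

In a functional assay on SW480 cells (Homo sapiens) for antiproliferative activity, read by MTT assay, with a stated time of 48 h (on this read-out lower numbers stand for stronger inhibition and higher numbers for weaker inhibition), compound 3 `CCCCCCCCCCCC(CCO)n1cnc2c(OC)ncnc21` gives 9700 nM. Among the compounds with values here, that is higher than the only other exact number in this small set, from compound 2 `CCCCCCCCCCC(CCO)n1cnc2c(N(C)C)ncnc21` at 3320 nM. Compound 1 `CCCCCCCC(CCO)n1cnc2c(N(C)C)ncnc21` shows > 50000 nM, which is a limit of the assay and not a number.

Compound 4 `CCCCCCCCCCCC(CCO)n1cnc2c(N(C)C)ncnc21` differs from compound 3 in one place, dimethylamino in place of methoxy on an aromatic carbon. Within the data shown here, no measured step makes this swap directly. Among the measured compounds shown here, the only measured step, propyl in place of hydrogen on a saturated chain carbon, is large, an at least 15-fold lower number from compound 1 to compound 2 (1.17 log units; beyond the scatter), and its size rests on (the limit of > 50000 nM in this assay, at which 1 of the 3 values shown sits). It shows that the chain can matter among these compounds, yet compound 3 and compound 4 share the same chain, so this step says little about the swap. The closest guide is compound 2, which already carries dimethylamino and gives 3320 nM, though its chain differs from that of compound 4. In this assay, a moderately lower number is therefore expected, with an estimated 2.8-fold lower number from compound 3 to compound 4 (0.44 log units; beyond the scatter). For compound 4 the estimated value is 3500 nM, with an expected range from 1300 nM to 9000 nM.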

Compound 4, half-maximal inhibitory concentration: 11800 nM
Compound 4: the middle estimate sits 3.4-fold (0.53 log units) below what was measured; measured number above the stated range.
By their numbers in this assay, from the lowest: compound 2; then compounds 3 and 4 (each within the scatter of the next). At a limit, above all of these: compound 1.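

In this assay, dimethylamino in place of methoxy on an aromatic carbon gives a 1.2-fold higher number from compound 3 to compound 4 (0.09 log units; within the scatter), so on this chain the two groups cannot be told apart at this position. The chain makes the readable difference: a methyl added to the chain gives a 3.6-fold higher number from compound 2 to compound 4 (0.55 log units; beyond the scatter), so among these dimethylamino compounds the number does not simply keep falling as the chain grows. A longer extension of the chain gives an at least 4.2-fold lower number from compound 1 to compound 4 (0.62 log units; beyond the scatter), and the size of this step is only a bound, resting on a limit of the assay: the limit of > 50000 nM in this assay, at which 1 of the 4 values shown sits.

From the compounds shown here alone, the swap is seen on one chain only, so whether methoxy and dimethylamino would also match on the chain of compound 2 stays open. Also open, going by these compounds, is what a plain amino group on this aromatic carbon, or a chain longer than that of compound 4, would give.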